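A methyl group added at the assay limit

The source may hold more compounds than are shown below. What is called first, only, known or untested is meant among the compounds shown, and "the series" means these compounds.

In a functional assay on HeLa cells (Homo sapiens) for antiproliferative activity, read by MTT assay, with a stated time of 72 h (on this read-out lower numbers stand for stronger inhibition and higher numbers for weaker inhibition), compound 1 (`CCCn1ccnc1-c1cc(OC)c(OC)c(OC)c1`) gives > 100000 nM as a limit and not a number. Compound 2 (`COc1cc(-c2nccn2C(C)C)cc(OC)c1OC`) likewise gives > 100000 nM as a limit. Compound 3 (`COc1cc(-c2nccn2S(=O)(=O)c2ccccc2)cc(OC)c1OC`) also gives > 100000 nM as a limit and so stands level with the other two. The evidence so far is the limit of > 100000 nM in this assay, at which 3 of the 3 values shown sit, and it offers no number to build on. Compound 4 (`COc1cc(-c2nccn2S(=O)(=O)c2ccc(C)cc2)cc(OC)c1OC`) carries methyl in place of hydrogen on an aromatic carbon, para to a large group (methyl in place of hydrogen on an aromatic carbon). Going by the values given here, the only measured step is a step that the two limits leave unreadable from compound 1 to compound 2 and it concerns another place in the structure. The estimated step of a number no higher from compound 3 to compound 4 (the limit leaves the size open) is therefore expected to stay within the scatter of this assay in either direction. Compound 4 is estimated at 100000 nM with 20000 nM to 150000 nM as the expected range.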

Compound 4, half-maximal inhibitory concentration: > 100000 nM
Compound 4: only a limit was reported (the forecaster's own chance of this, stated with the estimate: 80%); the middle value sits exactly at the limit.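

Compound 1, compound 2, compound 3 and compound 4 all sit at a limit and not at a number, so neither step between them can be read. Whether any change to the shared core gives a measurable potency stays open: the limit of > 100000 nM in this assay, at which 4 of the 4 values shown sit.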